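Fluorine Position on the Hydrazide Aryl Ring in Ovarian Cells

This account rests on a few compounds, and the source may have more. Where it says the series, first, only, none or still open, it means among the compounds named here.

Measured compounds:
compound 1, `O=C(NNc1ccccc1F)c1ccc(NS(=O)(=O)c2cnc(O)nc2O)cc1`: > 20000 nM
compound 2, `O=C(NNc1ccc(F)cc1)c1ccc(NS(=O)(=O)c2cnc(O)nc2O)cc1`: > 20000 nM
compound 3, `O=C(NNc1ccccc1F)c1ccccc1NS(=O)(=O)c1cnc(O)nc1O`: 9570 nM

In a functional assay on OVCAR-3 cells (Homo sapiens) for antiproliferative activity, read by MTT assay, with a stated time of 24 h (on this read-out lower numbers stand for stronger inhibition and higher numbers for weaker inhibition), compound 1 gives only a limit, > 20000 nM. Compound 2 likewise gives only a limit, > 20000 nM. For the measured compounds named here, compound 3 is the one compound with a number, 9570 nM. The difference between the core of compound 1 and the core of compound 3 is not broken down here.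

The change from compound 1 to compound 2 is 4-fluorophenyl in place of 2-fluorophenyl on an amine nitrogen. Because both values sit at the limit of > 20000 nM in this assay, at which 2 of the 3 values shown sit, the step that the two limits leave unreadable from compound 1 to compound 2 cannot be read in size.

Compound 4, `O=C(NNc1ccc(F)cc1)c1ccccc1NS(=O)(=O)c1cnc(O)nc1O`, carries the same change on the core of compound 3: 4-fluorophenyl in place of 2-fluorophenyl on an amine nitrogen. Nothing measured tells how large this change is, so the expectation for compound 4 rests only on compound 3 with its 9570 nM and on the unreadable step from compound 1 to compound 2. The step from compound 3 to compound 4 is expected to be about a 1.3-fold higher number from compound 3 to compound 4 (0.10 log units; within the scatter). Compound 4 is therefore estimated at 12000 nM in this assay, between 5000 nM and 30000 nM.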

Compound 4, half-maximal inhibitory concentration: > 20000 nM
Compound 4: a limit, no number; the forecaster's own chance of this, stated with the estimate: 35%; middle value at least 1.6-fold (0.22 log units) from the limit.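

In this assay compound 4 gives > 20000 nM, which is a limit and not a number. On the core of compound 3, placing 4-fluorophenyl where 2-fluorophenyl stood on the amine nitrogen gives an at least 2.0-fold higher number from compound 3 to compound 4 (0.32 log units; beyond the scatter), so on this core the change clearly weakens inhibition, since a higher number here means weaker inhibition. This does not show how large the loss really is, nor whether it carries over from one core to another, because the step on the core of compound 1 cannot be read and the step on the core of compound 3 has only a bound on one side: the limit of > 20000 nM in this assay, at which 3 of the 4 values shown sit.

The compounds shown leave open whether the fluorine itself matters, since a plain phenyl ring, or a chlorine or a methoxy group in its place, does not appear among them. They also leave open how an amine or a carboxylic acid on this aryl ring would behave on either core.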